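Swapping methyl for dimethylamino on the styryl ring

This account rests on a few compounds, and the source may have more. Where it says the series, first, only, none or still open, it means among the compounds named here.

Measured so far:
compound 1, `CC(=O)OC[C@H]1O[C@@H](n2cc(CN3C(=O)/C(=C/c4ccc(C)cc4)c4ccccc43)nn2)[C@H](OC(C)=O)[C@@H](OC(C)=O)[C@@H]1OC(C)=O`, 16000 nM
compound 2, `CC(=O)OC[C@H]1O[C@@H](n2cc(CN3C(=O)/C(=C\c4ccc(C)cc4)c4ccccc43)nn2)[C@H](OC(C)=O)[C@@H](OC(C)=O)[C@@H]1OC(C)=O`, 16500 nM

In a functional assay on A549 cells (Homo sapiens) for cytotoxicity, read by sulforhodamine B assay, with a stated time of 48 h (a lower number here means a stronger inhibitor, a higher number a weaker inhibitor), compound 1 gives 16000 nM, and compound 2 gives 16500 nM. Going by the values given here, the only measured step, a 1.0-fold higher number from compound 1 to compound 2 (0.01 log units; within the scatter), rests on the fact that compounds 1 and 2 differ only in the configuration as drawn and does not move the number: compound 2 stands alongside compound 1, the two values lying within the scatter of each other.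

Compound 3, `CC(=O)OC[C@H]1O[C@@H](n2cc(CN3C(=O)/C(=C\c4ccc(N(C)C)cc4)c4ccccc43)nn2)[C@H](OC(C)=O)[C@@H](OC(C)=O)[C@@H]1OC(C)=O`, has not yet been measured. It differs from compound 2 in this way: dimethylamino in place of methyl on an aromatic carbon. Among the compounds with values here, no measured step touches that kind of change; the step from compound 1 to compound 2 concerns only the drawn configuration and says nothing about what a different group on that ring would do. With no guidance of this sort, a step of a 1.4-fold lower number from compound 2 to compound 3 (0.14 log units; within the scatter) is expected, with the range kept wide. Compound 3 is therefore estimated at 12000 nM in this assay, between 4000 nM and 40000 nM.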

Compound 3, half-maximal inhibitory concentration: 17700 nM
Compound 3: the middle estimate sits 1.5-fold (0.17 log units) below what was measured; the range from low to high includes it.
By their numbers in this assay, from the lowest: compounds 1, 2 and 3 (each within the scatter of the next).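

In this assay, placing dimethylamino instead of methyl on this aromatic carbon, para to a large group, gives a 1.1-fold higher number from compound 2 to compound 3 (0.03 log units; within the scatter). Going by these compounds alone, this is the first look at a change of group on the ring rather than a change of drawn configuration, and for this one pair, a group with more heavy atoms and a hydrogen-bond acceptor leaves the two compounds indistinguishable in this assay. No information given here bears on why this swap leaves the value within the scatter.

These compounds leave open whether a carboxylic acid, a primary amine or a longer alkyl chain at the same ring position would give a different value. They also leave open whether dimethylamino would behave the same with the double bond drawn in the other configuration, as in compound 1.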